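Triazolylmethyl spirooxindoles: where compound 3 stands, compound 4 expected

This account rests on a few compounds, and the source may have more. Where it says the series, first, only, none or still open, it means among the compounds named here.

Compound 1 `CC(=O)Nc1ccc(-n2nncc2CN2C(=O)C3(C(C#N)=C(N)Oc4c3c3nc5ccccc5nc3c3ccccc43)c3ccccc32)cc1` gives > 50000 nM, a limit of the assay.
Compound 2 `N#CC1=C(N)Oc2c(c3nc4ccccc4nc3c3ccccc23)C12C(=O)N(Cc1cnnn1-c1ccc(S(N)(=O)=O)cc1)c1ccccc12` gives 31200 nM.
Compound 3 `N#CC1=C(N)Oc2c(N)cc3nc4ccccc4nc3c2C12C(=O)N(Cc1cnnn1-c1ccccc1Cl)c1ccccc12` gives > 50000 nM, a limit of the assay.

All three were read in a functional assay on HCT-116 cells (Homo sapiens) for antiproliferative activity, read by MTT assay, with a stated time of 48 h; a higher number here means a weaker inhibitor, a lower number a stronger inhibitor. Of the shared core there are two variations here: the group on the phenyl that hangs from the triazole nitrogen, and an amino group on the fused ring system of compound 3 that compounds 1 and 2 lack. Among the measured compounds shown here, the one step measured between neighbours, an at least 1.6-fold lower number from compound 1 to compound 2 (0.20 log units; that floor lies within the scatter), is the only paired comparison available, and it sits at the floor of what can be told apart. Compound 3 stands at the limit, as do two of the three values (the limit of > 50000 nM in this assay, at which 2 of the 3 values shown sit), so its number is only a bound.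

Compound 4 `COc1ccc(-n2nncc2CN2C(=O)C3(C(C#N)=C(N)Oc4c(N)cc5nc6ccccc6nc5c43)c3ccccc32)cc1` keeps the amino-bearing core of compound 3 and differs only in the aryl on the triazole: 4-methoxyphenyl in place of 2-chlorophenyl on an aromatic nitrogen. For the measured compounds named here, no measured step touches this aryl position, and the one step that does change the aryl substituent, from compound 1 to compound 2, moved the number by an amount that lies within the scatter. No step beyond the scatter is therefore expected for a number no higher from compound 3 to compound 4 (the limit leaves the size open). Compound 4 is estimated at 50000 nM in this assay, with a range of 20000 nM to 120000 nM, and a limit again is the likelier outcome.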

Compound 4, half-maximal inhibitory concentration: > 50000 nM
Compound 4 ended at the assay's limit (the forecaster's own chance of this, stated with the estimate: 70%); the middle value sits exactly at the limit.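

Among the compounds shown here, compound 3 and compound 4 each give only a limit of the assay, so no step between them can be read: the limit of > 50000 nM in this assay, at which 3 of the 4 values shown sit. The compounds shown leave open whether 4-methoxyphenyl in place of 2-chlorophenyl changes antiproliferative activity at all on the core shared by compound 3 and compound 4.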